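Swapping the aryl group on the hydrazone of compound 2

This account rests on a few compounds, and the source may have more. Where it says the series, first, only, none or still open, it means among the compounds named here.

Compound 1 `CN(C)CCn1cnnc1-c1cc(Oc2ccc(NC(=O)N/N=C/c3ccc(F)cc3)cc2F)ccn1` gives 1790 nM in a functional assay on A549 cells (Homo sapiens) for cytotoxicity, read by MTT assay, with a stated time of 72 h; a lower number here means a stronger inhibitor, a higher number a weaker inhibitor.
Compound 2 `CN(C)CCn1cnnc1-c1cc(Oc2ccc(NC(=O)N/N=C/c3ccc(F)cc3F)cc2F)ccn1` gives 1870 nM in this assay.

Within the data shown here, these are the only two numbers so far. Compound 2 and compound 1 sit within the scatter of each other: the step of a 1.0-fold higher number from compound 1 to compound 2 (0.02 log units; within the scatter) is the whole of the measured record, and it shows that adding a fluoro to the aryl group on the hydrazone left the read-out unchanged.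

Compound 3 `CN(C)CCn1cnnc1-c1cc(Oc2ccc(NC(=O)N/N=C/c3cccc(Br)c3)cc2F)ccn1` takes the same shared core and changes that aryl group again: 3-bromophenyl in place of 2,4-difluorophenyl on a carbon with a double bond to nitrogen. Among the measured compounds shown here, only one measured step touches this ring, a 1.0-fold higher number from compound 1 to compound 2 (0.02 log units; within the scatter), and it was flat. Nothing measured speaks to bromine, or to removing both fluorines at once, so the evidence for a shift is thin. The expected step of a 1.1-fold higher number from compound 2 to compound 3 (0.03 log units; within the scatter) is therefore small and of no firm direction, with a wide range to reflect the unknown bromo substitution. Compound 3 is estimated at 2000 nM in this assay, between 700 nM and 6000 nM.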

Compound 3, half-maximal inhibitory concentration: 970 nM
The estimate for compound 3 lay 2.1-fold (0.31 log units) above the measured number; the range from low to high includes it.
By their numbers in this assay, from the lowest: compounds 3, 1 and 2 (each within the scatter of the next).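

The exchange of 2,4-difluorophenyl for 3-bromophenyl on a carbon with a double bond to nitrogen comes out as a 1.9-fold lower number from compound 2 to compound 3 (0.29 log units; within the scatter) in this assay, and the exchange of 4-fluorophenyl for 3-bromophenyl comes out as a 1.8-fold lower number from compound 1 to compound 3 (0.27 log units; within the scatter). The earlier pair varied only the fluoro substitution on this aryl group, whereas compound 3 carries bromo and no fluoro, and its number still stays within the scatter of both compound 1 and compound 2, so this wider change at this position gives no measurable shift in this series. Nothing on hand explains the numbers of these three compounds.

All three aryl groups shown carry halogen, so it remains open whether a phenyl group without any halogen would fall within the same scatter. On these data alone, it is also open whether an amine, a carboxylic acid or a methoxy group on this aryl ring would move the number beyond the scatter, or whether the insensitivity seen here holds only for halogens.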